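The compounds below may be only part of what the source reports. "The series", "measured", "known", "first", "only" and "open" are said of these compounds alone.

Compound 1, `COc1ccc(-c2nc3cc(C(C)=O)ccc3[nH]2)c(OC)c1`, in an ADME assay on Vero cells (Chlorocebus sabaeus) for cytotoxicity, read by MTT assay, with a stated time of 96 h; a higher number here means that more compound is tolerated, a lower number that less compound is tolerated: > 100000 nM, a limit of the assay rather than a number.
Compound 2, `COc1ccc(-c2nc3cc(/C(C)=N/NC(N)=O)ccc3[nH]2)c(OC)c1`: 80000 nM.
Compound 3, `CC(=O)c1ccc2c(c1)nc(-c1ccccc1)n2C1CCCCC1`: 80000 nM.

From compound 1 to compound 2 the change is a group of 7 heavy atoms (3 carbon, 3 nitrogen, 1 oxygen; no ring) in place of a group of 3 heavy atoms (2 carbon, 1 oxygen; no ring), on an aromatic carbon, and it gave an at least 1.2-fold lower number from compound 1 to compound 2 (0.09 log units; that floor lies within the scatter); that step is only a floor because compound 1 sits at the limit of > 100000 nM in this assay, at which 1 of the 3 values shown sits. Compound 3 carries a different core, and the difference between the two cores is not broken down here. Its value in this assay is level with that of compound 2, within the scatter. Going by the values given here, compound 4, `C/C(=N\NC(N)=O)c1ccc2c(c1)nc(-c1ccccc1)n2C1CCCCC1`, has not yet been measured; it differs from compound 3 by a group of 7 heavy atoms (3 carbon, 3 nitrogen, 1 oxygen; no ring) in place of a group of 3 heavy atoms (2 carbon, 1 oxygen; no ring), on an aromatic carbon, the same change as the one from compound 1 to compound 2, at the same place. Since that earlier step, an at least 1.2-fold lower number from compound 1 to compound 2 (0.09 log units; that floor lies within the scatter), stayed within the scatter, the step of a 1.2-fold lower number from compound 3 to compound 4 (0.09 log units; within the scatter) is expected to be small as well. Compound 4 is therefore estimated at 65000 nM, between 30000 nM and 150000 nM.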

Compound 4, half-maximal cytotoxic concentration: > 100000 nM
Compound 4: only a limit was reported (the forecaster's own chance of this, stated with the estimate: 20%); middle value at least 1.5-fold (0.18 log units) away from the limit.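

In this assay compound 4 gives > 100000 nM, a limit of the assay and not a number. Putting the same group in place of acetyl on this core gave an at least 1.2-fold higher number from compound 3 to compound 4 (0.09 log units; that floor lies within the scatter). The two steps point in opposite directions as printed, but this does not show that the change behaves differently on the two cores, nor that it carries over unchanged: the same change on two cores in this assay, an at least 1.2-fold lower number (0.09 log units; that floor lies within the scatter) from compound 1 to compound 2 and an at least 1.2-fold higher number (0.09 log units; that floor lies within the scatter) from compound 3 to compound 4; the limit leaves it open whether they differ

Going by these compounds, how far the values past the limit actually lie remains open: the limit of > 100000 nM in this assay, at which 2 of the 4 values shown sit. Also open is what an amine or a carboxylic acid in place of the acetyl group would give in this assay.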